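The compounds below may be only part of what the source reports. "The series", "measured", "known", "first", "only" and "open" are said of these compounds alone.

Compound 1 `COc1ccc(CN(C(=O)CSC(=S)N2CCN(C)CC2)c2cc(OC)c(OC)c(OC)c2)cc1` gives 1250 nM
Compound 2 `COc1ccc(CN(C(=O)CSC(=S)N2CCN(C(C)=O)CC2)c2cc(OC)c(OC)c(OC)c2)cc1` gives 370 nM
Compound 3 `COc1ccc(CN(C(=O)CSC(=S)N2CCN(Cc3ccc(C(C)(C)C)cc3)CC2)c2cc(OC)c(OC)c(OC)c2)cc1` gives 2140 nM

In a functional assay on KYSE-450 cells (Homo sapiens) for inhibition, read by CCK-8 assay, with a stated time of 48 h (on this read-out higher numbers stand for weaker inhibition and lower numbers for stronger inhibition), compound 2 at 370 nM has the lowest number of the three and stands beyond the scatter from both of the others. Compound 4 `COc1ccc(CN(C(=O)CSC(=S)N2CCCC2)c2cc(OC)c(OC)c(OC)c2)cc1` keeps the shared core but carries pyrrolidin-1-yl in place of 4-acetylpiperazin-1-yl on a thiocarbonyl carbon. Among the measured compounds shown here, two measured steps bear on this change, and in both the compound with the acetyl group holds the lower number: a 3.4-fold lower number from compound 1 to compound 2 (0.53 log units; beyond the scatter) and also a 5.8-fold higher number from compound 2 to compound 3 (0.76 log units; beyond the scatter) (both modest). Like compound 1 at 1250 nM and compound 3 at 2140 nM compound 4 has no acetyl group, so a rise of modest size is expected. For the measured compounds named here, this remains uncertain, as no measured compound carries pyrrolidin-1-yl. The expected change is a 2.4-fold higher number from compound 2 to compound 4 (0.39 log units; beyond the scatter) (toward weaker inhibition). Compound 4 is estimated at 900 nM (expected range 350 nM to 2300 nM).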

Compound 4, half-maximal inhibitory concentration: 13800 nM
Beside the measured number, compound 4's estimate is 15-fold (1.19 log units) below it, and the stated range ends below it.
By their numbers in this assay, from the lowest: compound 2; then compounds 1 and 3 (each within the scatter of the next); then compound 4.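

In this assay, among the compounds shown here, the group on the thiocarbonyl carbon turns out to matter far more than the earlier compounds suggested: they varied only the substituent on the piperazine ring and gave modest steps, whereas replacing the whole group gives a 37-fold higher number from compound 2 to compound 4 (1.57 log units; beyond the scatter) and an 11-fold higher number from compound 1 to compound 4 (1.04 log units; beyond the scatter), both large. Since compound 1 also has no acetyl group, the absence of acetyl cannot account for the high number of compound 4, so the change from a piperazin-1-yl group to pyrrolidin-1-yl carries weight of its own. No measurement here explains why this swap has so large an effect.

Still open, on these data alone, is whether ring size or the lost ring nitrogen matters more. Piperidin-1-yl, a six-membered ring with one nitrogen, and morpholin-4-yl, which has an oxygen in that place, would help to separate the two.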